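Compound 1 and a ring-closed urea analogue

The source may report more compounds than this note shows. Statements on the series, on what has been measured and on what is new or still open speak of the compounds shown alone.

Compound 1 `CCNC(=O)Nc1ccc(/C=C/c2cccc(Cl)c2)cc1`: 20000 nM
Compound 2 `CCNC(=O)Nc1ccc(/C=C\c2cccc(Cl)c2)cc1`: 32000 nM
Compound 3 `CCNC(=O)Nc1ccc(/C=C\c2cc(OC)c(OC)c(OC)c2)cc1`: 21000 nM

In a functional assay on MCF7 cells (Homo sapiens) for inhibition, read by sulforhodamine B assay, with a stated time of 48 h (a lower number here means a stronger inhibitor, a higher number a weaker inhibitor), compound 1 gives 20000 nM, which lies within the scatter of both compound 3 at 21000 nM and compound 2 at 32000 nM. The next compound, compound 4 `O=C1NCCN1c1ccc(/C=C/c2cccc(Cl)c2)cc1`, differs from compound 1 at a single place: 2-oxoimidazolidin-1-yl in place of (ethylcarbamoyl)amino on an aromatic carbon. In words, 2-oxoimidazolidin-1-yl stands in place of (ethylcarbamoyl)amino on an aromatic carbon.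

Within the data shown here, only one measured step is available, a 1.6-fold higher number from compound 1 to compound 2 (0.20 log units; within the scatter), and it concerns (the fact that compounds 1 and 2 differ only in the configuration as drawn). Among the measured compounds shown here, it leaves the (ethylcarbamoyl)amino group untouched, so it bears on this change only indirectly, and no measured compound carries the new group. A step beyond the scatter in this assay is therefore not expected, and no direction can be favoured. The expected change is a 1.1-fold higher number from compound 1 to compound 4 (0.04 log units; within the scatter). Compound 4 is estimated at 22000 nM, with an expected range of 8000 nM to 60000 nM.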

Compound 4, half-maximal inhibitory concentration: 20000 nM
Compound 4: the middle estimate sits 1.1-fold (0.04 log units) above what was measured; the measured number falls inside the stated range.
By their numbers in this assay, from the lowest: compounds 1, 4, 3 and 2 (each within the scatter of the next).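

In this assay, replacing (ethylcarbamoyl)amino with 2-oxoimidazolidin-1-yl gives no change at the digits printed from compound 1 to compound 4 (within the scatter). Among these compounds, the earlier compounds all kept the (ethylcarbamoyl)amino group, so this is the first reading at this position: here, an open group and a five-membered non-aromatic ring on the same aromatic carbon cannot be told apart in this assay. The only available fact about these compounds concerns their drawn configuration and does not bear on this change.

As far as these compounds go, it remains open whether an amine or a carboxylic acid on this aromatic carbon, or a longer chain in place of the ethyl group of the urea, would give a step beyond the scatter. Also open, from the compounds shown here alone, is whether 2-oxoimidazolidin-1-yl would read the same with the double bond drawn Z, as in compound 2.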